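This account rests on a few compounds, and the source may have more. Where it says the series, first, only, none or still open, it means among the compounds named here.

Measured in an ADME assay on cells (Hepatocyte, Homo sapiens) for metabolic stability, with a stated time of 30 min; on this read-out higher numbers stand for a more stable compound and lower numbers for a less stable compound:
- compound 1 `NC1CCC(CN2CCN(c3cc(=O)c4cc(C(F)(F)F)cc([N+](=O)[O-])c4s3)CC2)CC1`: 83.6%
- compound 2 `O=c1cc(N2CCN(CC3CCC(NS(=O)(=O)c4ccccc4)CC3)CC2)sc2c([N+](=O)[O-])cc(C(F)(F)F)cc12`: 90.8%
- compound 3 `O=c1cc(N2CCN(CC3CCCCC3)CC2)sc2c([N+](=O)[O-])cc(C(F)(F)F)cc12`: 82.4%

On this assay, compound 3 gives 82.4%, which is within the scatter of both other compounds. Compound 4 `COc1ccc(C(=O)OC2CCC(CN3CCN(c4cc(=O)c5cc(C(F)(F)F)cc([N+](=O)[O-])c5s4)CC3)CC2)cc1` differs from it by one change: ((4-methoxyphenyl)carbonyl)oxy in place of hydrogen on a saturated ring carbon. The closest evidence is hydrogen replacing other groups on a saturated ring carbon, as in a number 1.2 percentage points lower from compound 1 to compound 3 (within the scatter) and a number 8.4 percentage points lower from compound 2 to compound 3 (within the scatter). Both steps stay within the scatter, which argues for a small effect. However, no measured compound carries this carbonyl-oxy link, so a modest fall is allowed for. The expected change is a number 6.4 percentage points lower from compound 3 to compound 4 (within the scatter), not clearly beyond the scatter. Compound 4 is estimated at 76%, with an expected range of 52% to 92%.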

Compound 4, percent of the compound remaining: 12.2%
The estimate for compound 4 lay 63.8 percentage points above the measured number; measured number outside the range, below it.
By their numbers in this assay, from the lowest: compound 4; then compounds 3, 1 and 2 (each within the scatter of the next).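

In this assay, the saturated ring carbon proves sensitive to what it carries: ((4-methoxyphenyl)carbonyl)oxy in place of hydrogen gives a number 70.2 percentage points lower from compound 3 to compound 4 (beyond the scatter). The same group gives a number 71.4 percentage points lower from compound 1 to compound 4 (beyond the scatter) in place of amino and a number 78.6 percentage points lower from compound 2 to compound 4 (beyond the scatter) in place of (phenylsulfonyl)amino, so the three earlier groups, all within the scatter of one another, did not show how far the number can fall at this position. Nothing available here accounts for the drop.

The compounds shown leave open whether the fall belongs to the carbonyl-oxy link or to the 4-methoxyphenyl part. An amide link to the same 4-methoxyphenyl group, or a hydroxyl alone on that ring carbon, would help separate the two.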